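A few compounds are considered here, and "the series" means these few. Any claim that something is new, unique, unknown or untested is made for them only; others in the source may bear on it.

Compound 1 `CN(C)CCNc1nc(-c2ccc(NC(=O)Nc3ccccc3)cc2)nc2ccsc12` and compound 2 `CN(C)CCNc1nc(-c2ccc(NC(=O)Nc3ccc(F)cc3)cc2)nc2c(Cl)c(Cl)sc12` were both tested in a functional assay on HT-29 cells (Homo sapiens) for cytotoxicity, read by MTT assay, with a stated time of 72 h; on this read-out higher numbers stand for weaker inhibition and lower numbers for stronger inhibition. In this assay compound 1 gives 620 nM, and compound 2 gives 890 nM; the two numbers lie within the usual scatter of each other, so the two compounds cannot be told apart on this read-out. Compound 3 `CN(C)CCNc1nc(-c2ccc(NC(=O)Nc3ccccc3Cl)cc2)nc2ccsc12` has not yet been measured. It differs from compound 1 by chloro in place of hydrogen on an aromatic carbon. Among the compounds with values here, no measured pair shows this change, so no step beyond the scatter is expected in either direction. Compound 3 is expected to give 600 nM, within a range from 250 nM to 1500 nM, which means an expected step of a 1.0-fold lower number from compound 1 to compound 3 (0.01 log units; within the scatter) that stays within the scatter.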

Compound 3, half-maximal inhibitory concentration: 310 nM
Compound 3: the middle estimate sits 1.9-fold (0.29 log units) above what was measured; the range from low to high includes it.
By their numbers in this assay, from the lowest: compounds 3, 1 and 2 (each within the scatter of the next, the first and the last beyond it).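

In this assay, within the data shown here, the change from phenyl to 2-chlorophenyl gives a 2.0-fold lower number from compound 1 to compound 3 (0.30 log units; within the scatter) and is the first step between compounds that differ in one place. A chloro on this aromatic carbon, ortho to a large group, thus leaves the cytotoxicity read-out within the scatter of the parent hydrogen compound, with no loss on this read-out. Nothing measured here bears on the reason for this result.

From the compounds shown here alone, whether an amine, a methoxy group or a bromo at this place would give a step beyond the scatter stays open, as does the effect of chloro elsewhere on this ring.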